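Swapping Bromo for Fluoro in a Weak Antiproliferative Series

A few compounds are considered here, and "the series" means these few. Any claim that something is new, unique, unknown or untested is made for them only; others in the source may bear on it.

Measured compounds:
compound 1 `O=S(=O)(Nc1ccc2cc[nH]c2c1)c1ccc(Br)cc1` gives 40100 nM
compound 2 `O=C(Nc1ccc2cc[nH]c2c1)c1cccc(C(F)(F)F)c1` gives 28200 nM
compound 3 `O=C(Nc1ccc2cc[nH]c2c1)c1ccc(C(F)(F)F)cc1` gives 51300 nM

All three measured compounds were tested in a functional assay on T47D cells (Homo sapiens) for antiproliferative activity, read by MTT assay, with a stated time of 24 h; on this read-out higher numbers stand for weaker inhibition and lower numbers for stronger inhibition. Compound 1 stands second highest of the three numbers. Its nearest neighbour is compound 3, whose number is higher by an amount within the usual scatter, and its furthest is compound 2, whose number is lower, again within the scatter. None of the three can therefore be ranked against the others; all sit in the same weak range.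

Compound 4 `O=S(=O)(Nc1ccc2cc[nH]c2c1)c1ccc(F)cc1` has not yet been measured. It differs from compound 1 in one place: fluoro in place of bromo on an aromatic carbon. Among the compounds with values here, no step between measured compounds of this kind exists here, so there is nothing to calibrate the change against. The three measured values show that varying the group on the outer ring, across both amide and sulfonamide links, leaves the numbers within scatter of one another. The expectation is a step of at most the size of the scatter, with no clear direction, so that a 1.2-fold higher number from compound 1 to compound 4 (0.08 log units; within the scatter) is estimated to be small. Compound 4 is expected to give about 48000 nM, with a range from 20000 nM to 120000 nM.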

Compound 4, half-maximal inhibitory concentration: 33000 nM
Beside the measured number, compound 4's estimate is 1.5-fold (0.16 log units) above it; the range from low to high includes it.
By their numbers in this assay, from the lowest: compounds 2, 4, 1 and 3 (each within the scatter of the next).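

In this assay the exchange of bromo for fluoro on an aromatic carbon, para to a large group, gives a 1.2-fold lower number from compound 1 to compound 4 (0.08 log units; within the scatter) and so provides the only single-change step among these compounds. At this position, with the sulfonamide link kept, the two halogens therefore cannot be told apart, and compound 4 stays in the same weak range as compound 1. No measurement is available here that would explain this result.

As far as these compounds go, whether this position would respond more clearly to an amine, a carboxylic acid or a longer chain remains open. From the compounds shown here alone, it is also open whether the same exchange of bromo for fluoro would leave the number similarly unmoved on a compound with the amide link.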